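Extending the piperazine substituent from methyl to butyl

The source may report more compounds than this note shows. Statements on the series, on what has been measured and on what is new or still open speak of the compounds shown alone.

Compound 1 `CCn1c(=O)n(C(=O)NCCN2CCN(C)CC2)c2ccccc21` gives 75.4 nM in an assay on isolated protein (striatum) for binding affinity to 5-hydroxytryptamine receptor 4 (Cavia porcellus), read by radioligand binding (on this read-out lower numbers stand for stronger inhibition and higher numbers for weaker inhibition), the lowest of the two numbers measured here; compound 2 `CN1CCN(CCNC(=O)n2c(=O)n(C)c3ccccc32)CC1` gives 306 nM, and the step of a 4.1-fold higher number from compound 1 to compound 2 (0.61 log units; beyond the scatter) changes a group elsewhere on the core. Compound 3 `CCCCN1CCN(CCNC(=O)n2c(=O)n(CC)c3ccccc32)CC1` differs from compound 1 by propyl in place of hydrogen on a saturated chain carbon bound to an amine nitrogen in a ring. Within the data shown here, no measured step touches this position, so the single step at the other site gives no direct guide, and no change beyond the scatter is assumed. The expected step is a 1.1-fold higher number from compound 1 to compound 3 (0.03 log units; within the scatter). Compound 3 is therefore expected to give about 80 nM, within 20 nM to 320 nM.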

Compound 3, inhibition constant: 34.1 nM
Compound 3: middle estimate off by 2.3-fold (0.37 log units), on the high side; the measured number falls inside the stated range.
By their numbers in this assay, from the lowest: compound 3; then compound 1; then compound 2.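

In this assay, propyl in place of hydrogen on a saturated chain carbon bound to an amine nitrogen in a ring gives a 2.2-fold lower number from compound 1 to compound 3 (0.34 log units; beyond the scatter) and so lowers the number. Among these compounds, this shows that the position, which no earlier step touched, responds to the change and accepts butyl in place of methyl. It rests on this single modest step, and no evidence at hand accounts for the shift.

The compounds shown leave open whether a longer chain such as hexyl would lower the number further. From the compounds shown here alone, how a benzyl group would compare at this position also remains open.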